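Cyano in Place of Methyl on a Fused Ring

The source may report more compounds than this note shows. Statements on the series, on what has been measured and on what is new or still open speak of the compounds shown alone.

Measured compounds:
compound 1, `O=C(O)CC(c1ccc(F)cc1)c1ccc(OCC2COc3ccc(Cl)cc3O2)cc1`, 83%
compound 2, `CC#C[C@@H](CC(=O)O)c1ccc(OC[C@H]2COc3c(Cl)cccc3O2)cc1`, 81%
compound 3, `CC#C[C@@H](CC(=O)O)c1ccc(OC[C@H]2COc3ccc(C)cc3O2)cc1`, 78%

Of the compounds shown here, three have been tested in a functional assay on HEK293 cells for agonist activity at Free fatty acid receptor 1 (Homo sapiens), read by fluorescence and calcium flux, with a stated time of 10 min; a higher number here means a larger maximal response, a lower number a smaller maximal response. Compound 1 gives 83%, compound 2 gives 81%, and compound 3 gives 78%. The number for compound 3 sits at the low end of the three, but its gap to compound 2 and its gap to compound 1 both fall within the usual scatter of this assay, so no ranking of the three can be drawn from these values; all three are, in practice, indistinguishable maximal responses.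

Compound 4, `CC#C[C@@H](CC(=O)O)c1ccc(OC[C@H]2COc3ccc(C#N)cc3O2)cc1`, has not yet been measured. It differs from compound 3 in one place: cyano in place of methyl on an aromatic carbon. Everything else, including the shared core with its acid side chain and the propynyl group, is kept.

Among the compounds with values here, no step between two measured compounds that differ in one place is available, so the expectation for compound 4 rests on how little the three measured numbers move. Compound 4 is expected to give about 78% in this assay, somewhere between 64% and 92%. That means an estimated step of no change at the digits printed from compound 3 to compound 4 (within the scatter), which is expected to lie within the scatter rather than beyond it in either direction.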

Compound 4, largest response reached (Emax), in percent of the reference or control that the assay uses: 60%
Compound 4: the middle estimate sits 18 percentage points above what was measured; the measured number lies below the stated range.
By their numbers in this assay, from the lowest: compound 4; then compounds 3, 2 and 1 (each within the scatter of the next).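

In this assay, cyano in place of methyl on an aromatic carbon, meta to a fused ring and para to a fused ring, gives a number 18 percentage points lower from compound 3 to compound 4 (beyond the scatter). Within the data shown here, this is the first step that differs in one place, and it shows that the maximal response can respond to the group at this position, whereas the numbers of the earlier compounds lay within the scatter of one another and revealed no such sensitivity. Nothing shown here speaks to what lies behind the step.

Going by these compounds, whether the lower maximal response belongs to cyano alone stays open, as does whether a methoxy group, a primary amide or a bare hydrogen on the same aromatic carbon would keep the response of compound 3 or lower it in the same way. On these data alone, it is also open whether the same exchange would have a similar effect with the fluorophenyl group of compound 1 in place of the propynyl group, and whether the concentration needed for a response shifts along with the maximal response.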